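Aryl Group Replacement on a Shared Nitrocatechol-Free Core

The source may report more compounds than this note shows. Statements on the series, on what has been measured and on what is new or still open speak of the compounds shown alone.

Measured in an assay on isolated protein for inhibition of Amine oxidase [flavin-containing] B (Homo sapiens), read by fluorescence; a higher number here means a weaker inhibitor, a lower number a stronger inhibitor:
Compound 1 `O=C(/C=C/c1cccs1)c1cc(O)c(O)c([N+](=O)[O-])c1`: 62900 nM
Compound 2 `O=C(/C=C/c1cccc(O)c1)c1cc(O)c(O)c([N+](=O)[O-])c1`: 55800 nM
Compound 3 `O=C(/C=C/c1ccsc1)c1cc(O)c(O)c([N+](=O)[O-])c1`: 42100 nM

Compound 3 gives the lowest of the three numbers, yet the steps reaching it are a 1.3-fold lower number from compound 2 to compound 3 (0.12 log units; within the scatter) and a 1.5-fold lower number from compound 1 to compound 3 (0.17 log units; within the scatter), both within the scatter, as is a 1.1-fold lower number from compound 1 to compound 2 (0.05 log units; within the scatter). The three compounds are therefore indistinguishable on these data.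

Compound 4 `Cn1cc(/C=C/C(=O)c2cc(O)c(O)c([N+](=O)[O-])c2)cn1` has not yet been measured. It differs from compound 3 by 1-methyl-1H-pyrazol-4-yl in place of thiophen-3-yl on a double-bonded chain carbon bound to a double-bonded chain carbon. For the measured compounds named here, no measured step involves a pyrazole, but every exchange of the group on that chain carbon so far has left the number within the scatter, so no step beyond the scatter is expected in this assay. For compound 4 the estimate is 50000 nM, with a range from 20000 nM to 130000 nM. That estimate for compound 4 amounts to an expected 1.2-fold higher number from compound 3 to compound 4 (0.07 log units; within the scatter).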

Compound 4, half-maximal inhibitory concentration: 66200 nM
Compound 4: middle estimate off by 1.3-fold (0.12 log units), on the low side; low and high end bracket the measured number.
By their numbers in this assay, from the lowest: compounds 3, 2, 1 and 4 (each within the scatter of the next).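

In this assay the 1-methyl-1H-pyrazol-4-yl group, the only group shown with two ring hetero atoms, gives a 1.6-fold higher number from compound 3 to compound 4 (0.20 log units; within the scatter) and a 1.2-fold higher number from compound 2 to compound 4 (0.07 log units; within the scatter) and a 1.1-fold higher number from compound 1 to compound 4 (0.02 log units; within the scatter). All four compounds therefore remain indistinguishable, and this position on a double-bonded chain carbon has now taken a methyl-bearing ring without any separation in the number. Nothing shown explains this flat response. On these data alone, whether an amine, a carboxylic acid or a longer chain at this place would move the number beyond the scatter stays open. So does whether any change to the shared core would do so.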